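Volume of distribution across a shared core: a third analogue

The source may report more compounds than this note shows. Statements on the series, on what has been measured and on what is new or still open speak of the compounds shown alone.

Measured compounds:
compound 1 `CCn1c(-c2cnc(C)nc2)nc2c(N[C@H]3CCN(C(=O)N4CC(OC)C4)C3)ncnc21`: 4.8 L/kg
compound 2 `CCn1c(-c2cnc(C)nc2)nc2c(N[C@H]3CCN(C(=O)C4CC4)C3)ncnc21`: 6.3 L/kg
compound 3 `CCn1c(-c2ccc(C(F)(F)F)nc2)nc2c(O[C@H]3CCN(C(=O)C4CC4)C3)ncnc21`: 8.3 L/kg

Three compounds were characterised in an ADME assay (Rattus norvegicus, strain Wistar Han) for pharmacokinetics; on this read-out lower numbers stand for narrower distribution and higher numbers for wider distribution into tissues. Compound 2 gives 6.3 L/kg, and compound 1 gives 4.8 L/kg; the change between them is 3-methoxyazetidin-1-yl in place of cyclopropyl on a carbonyl carbon, and the resulting step is a 1.3-fold lower number from compound 2 to compound 1 (0.12 log units; within the scatter). Compound 3 gives 8.3 L/kg; how its core differs from that of compound 2 is not broken down here. Compound 4 `CCn1c(-c2ccc(C(F)(F)F)nc2)nc2c(O[C@H]3CCN(C(=O)N4CC(OC)C4)C3)ncnc21` has not yet been measured in this assay. It carries the same change relative to compound 3, namely (3-methoxyazetidin-1-yl in place of cyclopropyl on a carbonyl carbon). Since the earlier occurrence of this change gave a 1.3-fold lower number from compound 2 to compound 1 (0.12 log units; within the scatter), a comparably small step is expected from compound 3 to compound 4, estimated as a 1.3-fold lower number from compound 3 to compound 4 (0.11 log units; within the scatter). The value for compound 4 is therefore expected to be about 6.4 L/kg, with a likely range from 4 L/kg to 11 L/kg.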

Compound 4, volume of distribution: 4.2 L/kg
Compound 4: the middle estimate sits 1.5-fold (0.18 log units) above what was measured; the measured number falls inside the stated range.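

In this assay, putting 3-methoxyazetidin-1-yl in place of cyclopropyl on the carbonyl carbon gives a 2.0-fold lower number from compound 3 to compound 4 (0.30 log units; within the scatter). Set beside the earlier case, the two steps do not differ measurably: the same change on two cores in this assay, a 1.3-fold lower number (0.12 log units; within the scatter) from compound 2 to compound 1 and a 2.0-fold lower number (0.30 log units; within the scatter) from compound 3 to compound 4, 1.5-fold (0.18 log units) apart, within the scatter of two such steps. The change therefore carries over between these two cores without a detectable difference in step size, but each step lies within the scatter, so this does not show that the change has a real effect on the read-out, and two cores say nothing about others.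

The compounds shown leave open whether another group on the carbonyl carbon, such as a dimethylamino group or a longer alkyl chain, would give a step beyond the scatter. From the compounds shown here alone, it also remains open how the change behaves on a core carrying a carboxylic acid.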